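Swapping an amine for an isopropyl on the aryl ring

The source may report more compounds than this note shows. Statements on the series, on what has been measured and on what is new or still open speak of the compounds shown alone.

This study measures how well a set of related compounds slow the growth of A-375 melanoma cells in a functional assay on A-375 cells (Homo sapiens) for antiproliferative activity, read by trypan blue exclusion and crystal violet staining, with a stated time of 72 h; on this read-out higher numbers stand for weaker inhibition and lower numbers for stronger inhibition. Compound 1, `CCCC(=O)NC(c1ccc(N(CC)CC)cc1)c1cc(Cl)c2cccnc2c1O`, gives 130 nM in this assay, the lowest of the two numbers recorded. Compound 2, `CCCCC(=O)NC(c1ccc(Cl)c(Cl)c1)c1ccc2cccnc2c1O`, gives 320 nM in this assay, a weaker result that lies beyond the usual scatter of the measurement. Compound 3, `CCCCC(=O)NCc1ccc2cccnc2c1O`, is recorded as "nd" (no result reported) in this assay, that is, with no result reported, so it adds nothing to the comparison. Compounds 1 and 2 differ in several places at once, so their gap cannot be assigned to any single change.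

The next compound, compound 4, `CCCC(=O)NC(c1ccc(C(C)C)cc1)c1cc(Cl)c2cccnc2c1O`, is built from compound 1 by one change: isopropyl in place of diethylamino on an aromatic carbon. Going by the values given here, no measured pair shows this change on its own, so the size of its effect is unknown. A moderate step is expected, a 1.5-fold higher number from compound 1 to compound 4 (0.19 log units; within the scatter), leaning toward weaker inhibition but possibly within the scatter. Compound 4 is therefore estimated at 200 nM in this assay, with a likely range from 70 nM to 600 nM.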

Compound 4, half-maximal inhibitory concentration: 120 nM
Compound 4: the middle estimate sits 1.7-fold (0.22 log units) above what was measured, within the range that was stated.
By their numbers in this assay, from the lowest: compounds 4 and 1 (each within the scatter of the next); then compound 2.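

In this assay, going by these compounds alone, the swap of diethylamino for isopropyl gives a 1.1-fold lower number from compound 1 to compound 4 (0.03 log units; within the scatter) and is the first step here that isolates a single change, since compounds 1 and 2 differ in several places at once. Compound 4 and compound 1 cannot be told apart on this read-out, even though the swap removes the nitrogen and the hydrogen-bond acceptor it counts as, and goes from 5 heavy atoms to 3. At this place on the aromatic ring, then, at least in this pair, neither that nitrogen nor a group of the size of diethylamino is required for a number in this range, and no supporting measurement is available to explain the outcome.

On these data alone, what remains open is how much variety this position accepts, as one matched pair cannot show whether a carboxylic acid, a primary amine or a longer alkyl chain in the same place would fit the same picture. As far as these compounds go, it is also open whether the same swap would give a similar step on a compound with a different amide chain or without the chlorine on the core of compound 1.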